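The compounds below may be only part of what the source reports. "The series", "measured", "known", "first", "only" and "open" are said of these compounds alone.

For the measured compounds named here, compound 2 `Cc1ccc(C(=O)Nc2cc(-c3ccccc3)nn2-c2ccccc2)cn1` shows the lowest of the two numbers so far in an assay on HEK293 cells for displacement of a labelled ligand from metabotropic glutamate receptor 5 (Rattus norvegicus); on this read-out higher numbers stand for weaker inhibition and lower numbers for stronger inhibition: compound 2 gives 3480 nM, while its nearest neighbour, compound 1 `O=C(Nc1cc(-c2ccccc2)nn1-c1ccccc1)c1ccccc1`, gives 4180 nM, a gap of a 1.2-fold lower number from compound 1 to compound 2 (0.08 log units; within the scatter). Compound 3 `O=C(Nc1cc(-c2ccccc2)nn1-c1ccccc1)c1ccncc1` carries pyridin-4-yl in place of 6-methylpyridin-3-yl on a carbonyl carbon. Going by the values given here, only the step from compound 1 to compound 2 touches the same carbonyl-bound aryl group, and it stayed within the scatter, so for compound 3 no step beyond the scatter is expected in this assay, an expected step of a 1.0-fold higher number from compound 2 to compound 3 (0.00 log units; within the scatter). Compound 3 is therefore estimated at 3500 nM, with a range of 1400 nM to 9000 nM.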

Compound 3, inhibition constant: > 10000 nM
Compound 3: a limit, no number; the forecaster's own chance of this, stated with the estimate: 5%; middle value at least 2.8-fold (0.45 log units) from the limit.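

Compound 3 gives > 10000 nM in this assay, which is a limit of the assay and not a number. The aryl group on the carbonyl carbon, where the earlier change stayed within the scatter, now shows a step beyond it, with an at least 2.8-fold higher number from compound 2 to compound 3 (0.45 log units; beyond the scatter) and an at least 2.3-fold higher number from compound 1 to compound 3 (0.37 log units; beyond the scatter). Pyridin-4-yl thus gives weaker inhibition than either earlier group, and both steps remain open-ended: the limit of > 10000 nM in this assay, at which 1 of the 3 values shown sits.

Compound 3 differs from compound 2 in both the ring nitrogen's place and the methyl group, and these two changes are not separated here. From the compounds shown here alone, how an amine or a carboxylic acid on this ring would read also stays open.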